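This account rests on a few compounds, and the source may have more. Where it says the series, first, only, none or still open, it means among the compounds named here.

Compound 1 `Cc1ccccc1Nc1nc(Nc2ccc(N3CCN(C)CC3)cn2)ncc1Cl`: 5210 nM
Compound 2 `CN1CCN(c2ccc(Nc3ncc(Cl)c(NCc4ccc(F)cc4)n3)nc2)CC1`: 19300 nM

In a functional assay on MCF7 cells (Homo sapiens) for inhibition, read by CCK-8 assay, with a stated time of 48 h (a higher number here means a weaker inhibitor of growth, a lower number a stronger inhibitor of growth), compound 2 gives 19300 nM, the higher of the two numbers. Compound 3 `COc1ccc(CNc2nc(Nc3ccc(N4CCN(C)CC4)cn3)ncc2Cl)cc1` differs from it in one place: methoxy in place of fluoro on an aromatic carbon. Among the measured compounds shown here, the only measured step, a 3.7-fold higher number from compound 1 to compound 2 (0.57 log units; beyond the scatter), is modest and replaces the whole group on the nitrogen, so it bears on this smaller change only loosely. For the measured compounds named here, no measured step covers this swap, so no step beyond the scatter is expected in this assay, and neither direction is favoured. The estimated value for compound 3 is 16000 nM, with an expected range of 7000 nM to 35000 nM.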

Compound 3, concentration for 50% growth inhibition: 17300 nM
The estimate for compound 3 lay 1.1-fold (0.03 log units) below the measured number, and the stated range covers the measured number.
By their numbers in this assay, from the lowest: compound 1; then compounds 3 and 2 (each within the scatter of the next).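

In this assay, methoxy in place of fluoro on this aromatic carbon, para to a large group, gives a 1.1-fold lower number from compound 2 to compound 3 (0.05 log units; within the scatter), so this change leaves the number within the scatter. Placing 4-methoxybenzyl in place of 2-methylphenyl gives a 3.3-fold higher number from compound 1 to compound 3 (0.52 log units; beyond the scatter), showing that the modest rise seen with 4-fluorobenzyl recurs with a second benzyl group. No available evidence accounts for either step.

As far as these compounds go, it remains open whether an amine or a carboxylic acid at this para place would read differently from fluoro and methoxy. Also open, from the compounds shown here alone, is how a longer chain between the nitrogen and the ring would read.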